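Capping the ring amine of compound 2

The source may hold more compounds than are shown below. What is called first, only, known or untested is meant among the compounds shown, and "the series" means these compounds.

Compound 1 `CN1C/C(=C\c2ccc(C(F)(F)F)cc2)C(=O)/C(=C/c2cccnc2)C1`: 4830 nM
Compound 2 `O=C1/C(=C/c2cccnc2)CNC/C1=C\c1ccccc1F`: > 20000 nM

Both compounds were tested in a functional assay on SMMC-7721 cells (Homo sapiens) for cytotoxicity, read by MTT assay, with a stated time of 24 h; a lower number here means a stronger inhibitor, a higher number a weaker inhibitor. Compound 1 gives a real number there, 4830 nM. Compound 2 reaches only a limit of the assay, > 20000 nM, and so has no number of its own. That limit is the limit of > 20000 nM in this assay, at which 1 of the 2 values shown sits.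

The next compound to be tested is compound 3 `N#Cc1ccc(S(=O)(=O)N2C/C(=C\c3cccnc3)C(=O)/C(=C/c3ccccc3F)C2)cc1`. It keeps the core of compound 2 and changes it in one place: (4-cyanophenyl)sulfonyl in place of hydrogen on an amine nitrogen in a ring. In plain words, a (4-cyanophenyl)sulfonyl group replaces hydrogen on an amine nitrogen in a ring.

Within the data shown here, no measured pair shows what this kind of change does in this assay, so any forecast is uncertain. Among the measured compounds shown here, the only guide is compound 1, whose value of 4830 nM shows that a measurable result is possible in this assay. A clear move towards stronger inhibition is therefore expected. The expected change is an at least 6.6-fold lower number from compound 2 to compound 3 (0.82 log units; beyond the scatter). For compound 3 the estimated value is 3000 nM, with an expected range from 700 nM to 12000 nM.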

Compound 3, half-maximal inhibitory concentration: 15400 nM
Compound 3: middle estimate off by 5.1-fold (0.71 log units), on the low side, outside the stated range (above it).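

In this assay compound 2 gives > 20000 nM, which is a limit of the assay and not a number. Compound 3, with a (4-cyanophenyl)sulfonyl group on the amine nitrogen in the ring, gives a real reading of 15400 nM, so a compound on this core with this group at this position has a number of its own. The size of the change stays uncertain because compound 2 has no number of its own, which leaves only a floor, an at least 1.2-fold lower number from compound 2 to compound 3 (0.11 log units; that floor lies within the scatter), and the true step could be that small or much larger: the limit of > 20000 nM in this assay, at which 1 of the 3 values shown sits.

Compound 1 differs from compound 3 in more than one place, so the methyl group on its ring nitrogen cannot be compared directly with the (4-cyanophenyl)sulfonyl group. On these data alone, it also remains open whether the nitrile, the benzene ring or the sulfonyl link matters here, and what a phenylsulfonyl group without the nitrile, a methylsulfonyl group or an acetyl group would give on the same nitrogen.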